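The source may hold more compounds than are shown below. What is called first, only, known or untested is meant among the compounds shown, and "the series" means these compounds.

Measured compounds:
Compound 1 `O=C(Nc1cc(Sc2ncn[nH]2)c(O)c2ccccc12)c1ccc(Cl)cc1` gives 5520 nM in a functional assay on PC-3 cells (Homo sapiens) for antiproliferative activity, read by MTT assay, with a stated time of 48 h; a higher number here means a weaker inhibitor, a lower number a stronger inhibitor.
Compound 2 `O=C(Nc1cc(Sc2ncn[nH]2)c(O)c2ccccc12)c1cccc(Cl)c1` gives 85600 nM in this assay.
Compound 3 `COc1ccc(C(=O)Nc2cc(Sc3ncn[nH]3)c(O)c3ccccc23)cc1` gives only a limit of the assay, > 100000 nM, in this assay.

All three share one core and differ only in the group on the carbonyl carbon. Compound 3 stands at the weak end of the set: its value is a limit, namely (the limit of > 100000 nM in this assay, at which 1 of the 3 values shown sits), so no number is known for it. The step of an at least 18-fold higher number from compound 1 to compound 3 (1.25 log units; beyond the scatter) is large, while the step of an at least 1.1-fold higher number from compound 2 to compound 3 (0.06 log units; that floor lies within the scatter) has a floor that lies within the scatter. Compound 4 `O=C(Nc1cc(Sc2ncn[nH]2)c(O)c2ccccc12)c1ccc2ccccc2c1` carries the change (naphthalen-2-yl in place of 4-methoxyphenyl on a carbonyl carbon). Among the compounds with values here, none of the measured steps involves a naphthalen-2-yl, so none bears directly on this change; what the steps do show, through a 16-fold higher number from compound 1 to compound 2 (1.19 log units; beyond the scatter) and an at least 18-fold higher number from compound 1 to compound 3 (1.25 log units; beyond the scatter), is that the group on the carbonyl carbon can move the number widely. The step of an at least 2.5-fold lower number from compound 3 to compound 4 (0.39 log units; beyond the scatter) is therefore an expectation with wide uncertainty, pointing toward a lower number than the limit for compound 3. Compound 4 is expected to give about 40000 nM in this assay, with a range from 8000 nM to 150000 nM.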

Compound 4, half-maximal inhibitory concentration: > 100000 nM
Compound 4 ended at the assay's limit; the forecaster's own chance of this, stated with the estimate: 40%; middle value at least 2.5-fold (0.39 log units) from the limit.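

Compound 4 is a second compound that ends at a limit of this assay, so swapping one aromatic group for another on this carbonyl carbon does not by itself bring a measurable number: the limit of > 100000 nM in this assay, at which 2 of the 4 values shown sit.

Placing naphthalen-2-yl where 4-chlorophenyl stood gives an at least 18-fold higher number from compound 1 to compound 4 (1.25 log units; beyond the scatter), while placing it where 3-chlorophenyl stood gives an at least 1.1-fold higher number from compound 2 to compound 4 (0.06 log units; that floor lies within the scatter), so among these four compounds only the 4-chlorophenyl group stands clearly apart from the limit. Compound 3 and compound 4 both sit at a limit, so the step between them cannot be read, and nothing here ranks 4-methoxyphenyl against naphthalen-2-yl.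

On these data alone, what remains open is whether the low number of compound 1 depends on chlorine itself, which 4-fluorophenyl or 4-bromophenyl on the same carbonyl carbon could test. As far as these compounds go, it is also open whether a group without an aromatic ring, such as cyclohexyl or a short chain ending in an amine, would give a readable number in this assay.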